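Cytotoxicity limits and a new benzyl amine

A few compounds are considered here, and "the series" means these few. Any claim that something is new, unique, unknown or untested is made for them only; others in the source may bear on it.

Measured in an ADME assay on RAW264.7 cells (Mus musculus) for cytotoxicity, read by MTT assay; a lower number here means a stronger inhibitor, a higher number a weaker inhibitor:
- compound 1 `COc1cc(/C=C/c2nc(NC3CC3)c3sccc3n2)cc(OC)c1OC`: > 50000 nM, a limit
- compound 2 `COc1cc(/C=C/c2nc(Nc3ccc(C(F)(F)F)cc3)c3sccc3n2)cc(OC)c1OC`: > 50000 nM, a limit
- compound 3 `COc1cc(/C=C/c2nc(Nc3ccc(O)cc3)c3sccc3n2)cc(OC)c1OC`: > 50000 nM, a limit

Compound 3 gives > 50000 nM in this assay, and this is a limit, not a number. It shares that position with the other two compounds: the limit of > 50000 nM in this assay, at which 3 of the 3 values shown sit.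

Compound 4 `COc1cc(/C=C/c2nc(NCc3ccc(C)cc3)c3sccc3n2)cc(OC)c1OC` carries 4-methylbenzyl in place of the 4-hydroxyphenyl of compound 3, on a nitrogen on an aromatic ring, so that (4-hydroxyphenyl)amino becomes (4-methylbenzyl)amino: 4-methylbenzyl in place of 4-hydroxyphenyl on a nitrogen on an aromatic ring.

Three measured steps change the group at this same nitrogen: a step that the two limits leave unreadable from compound 1 to compound 2, a step that the two limits leave unreadable from compound 1 to compound 3 and a step that the two limits leave unreadable from compound 2 to compound 3. None of them has a size that can be read. Going by the values given here, still, cyclopropyl, 4-(trifluoromethyl)phenyl and 4-hydroxyphenyl all leave the reading at the same limit, and this is the only guide to the new group. No step beyond the scatter is therefore expected in this assay, and no direction can be given. The expected change is a step that the limit leaves unreadable from compound 3 to compound 4. The reading for compound 4 will most likely be a limit again. For compound 4 the estimated value is 60000 nM, with an expected range from 25000 nM to 120000 nM.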

Compound 4, half-maximal inhibitory concentration: > 50000 nM
Compound 4 gave a limit, no number; the forecaster's own chance of this, stated with the estimate: 80%; the middle value is on the limit's open side.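

In this assay, going by these compounds alone, compound 4 gives > 50000 nM, a limit and not a number, so no step to it from compound 1, compound 2 or compound 3 can be read. All four compounds stand together: the limit of > 50000 nM in this assay, at which 4 of the 4 values shown sit.

The compounds shown leave open whether changing the group on this nitrogen alters the reading at all, and in which direction.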